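The source may hold more compounds than are shown below. What is called first, only, known or untested is meant among the compounds shown, and "the series" means these compounds.

Of the compounds shown here, two built on a shared core have been tested in a functional assay on the whole organism (Tail, strain ICR) with Mus musculus as the target, in the tail flick test, with a stated time of 60 min, at a dose of 25 umol/kg by the oral route; a higher number here means a stronger effect of the compound at the dose given, a lower number a weaker effect. Compound 1, `O=C(CN(c1ncnc2c1ncn2C1CCCCO1)C1CC1)N[C@@H](CO)C(=O)OCc1ccccc1`, gives 46.7% in this assay. Compound 2, `NCCCC[C@H](NC(=O)CN(c1nc(Cl)nc2[nH]cnc12)C1CC1)C(=O)OCc1ccccc1`, differs from compound 1 in more than one place; compound 2 gives 41.2%. The gap between these two readings lies within the usual scatter of repeated measurements, so the data do not separate them, and compound 1 serves here only as the starting point for a single change.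

Compound 3, `NC(=O)C[C@H](NC(=O)CN(c1ncnc2c1ncn2C1CCCCO1)C1CC1)C(=O)OCc1ccccc1`, has not yet been measured. Its difference from compound 1 is carbamoyl in place of hydroxy on a saturated chain carbon, two bonds along the chain from an amide-type nitrogen and a carbonyl carbon. Among the measured compounds shown here, no pair of measured compounds shows this change, so there is nothing to say what it does to the read-out. With only the two readings to go on, the step of a number 4.7 percentage points lower from compound 1 to compound 3 (within the scatter) is expected to be small, with no clear direction and not beyond the scatter. Compound 3 is therefore expected to give about 42%, most likely falling between 25% and 60%.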

Compound 3, a percentage reported as activity, at one dose (the size of the read-out at that dose, not a potency): 30.5%
For compound 3 the middle estimate is 11.5 percentage points above the measured one; measured number inside the range.
By their numbers in this assay, from the lowest: compound 3; then compounds 2 and 1 (each within the scatter of the next).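

In this assay this position, on a saturated chain carbon two bonds along the chain from an amide-type nitrogen and a carbonyl carbon, responds to a change of group. Among the compounds shown here, with the rest of the molecule held the same, carbamoyl in place of hydroxy gives a number 16.2 percentage points lower from compound 1 to compound 3 (beyond the scatter) and so provides the first comparison here that isolates a single change, which compound 1 and compound 2, differing in more than one place, could not do. No measurement is at hand that accounts for the drop.

A single pair cannot tell whether the lower reading goes with the carbamoyl group itself or with the longer hydroxymethyl-to-carbamoylmethyl side chain, so a carboxylic acid, an amine or a longer chain ending in hydroxy at this position would be needed to separate those readings. On these data alone, it also remains open whether the same change would give a step of similar size on the core of compound 2, or whether it holds only on the core of compound 1.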